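The source may hold more compounds than are shown below. What is called first, only, known or untested is meant among the compounds shown, and "the series" means these compounds.

The three measured compounds share one core and differ only in the group on the carbon with a double bond to nitrogen. Compound 1 `Cn1c(=O)c(=O)n(C2CCCC2)c2nc(N/N=C/c3ccc(O)cc3)ncc21` carries a 4-hydroxyphenyl there, and in a functional assay on HCT-116 cells (Homo sapiens) for antiproliferative activity, read by MTT assay (a lower number here means a stronger inhibitor, a higher number a weaker inhibitor), compound 1 gives 72500 nM. Compound 3 `Cn1c(=O)c(=O)n(C2CCCC2)c2nc(N/N=C/c3ccc(S(C)(=O)=O)cc3)ncc21` carries a 4-(methylsulfonyl)phenyl, and in this assay compound 3 gives 86600 nM. The step of a 1.2-fold higher number from compound 1 to compound 3 (0.08 log units; within the scatter) lies within the scatter. Compound 2 `Cc1cccc(/C=N/Nc2ncc3c(n2)n(C2CCCC2)c(=O)c(=O)n3C)c1` carries a 3-methylphenyl. In this assay compound 2 gives > 100000 nM, which is a limit of the assay and not a number. Among the compounds with values here, compound 2 is the one compound sitting at the limit of > 100000 nM in this assay, at which 1 of the 3 values shown sits. The steps of an at least 1.3-fold higher number from compound 1 to compound 2 (0.13 log units; that floor lies within the scatter) and an at least 1.1-fold lower number from compound 2 to compound 3 (0.06 log units; that floor lies within the scatter) are therefore floors, and both floors lie within the scatter.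

Compound 4 `Cn1c(=O)c(=O)n(C2CCCC2)c2nc(N/N=C/c3cccc([N+](=O)[O-])c3)ncc21` has not been measured. It differs from compound 2 in one place: nitro in place of methyl on an aromatic carbon. Within the data shown here, the steps that bear on this change are those into and out of compound 2, and neither the step from compound 1 nor the step to compound 3 goes beyond the scatter. No step beyond the scatter is expected in this assay in either direction. Compound 4 is expected to give about 100000 nM, within a range from 50000 nM to 250000 nM. That estimate amounts to an expected step of a number no higher from compound 2 to compound 4 (the limit leaves the size open), with a fair chance that only a limit is reported.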

Compound 4, half-maximal inhibitory concentration: 15200 nM
The estimate for compound 4 lay 6.6-fold (0.82 log units) above the measured number; measured number outside the range, below it.
By their numbers in this assay, from the lowest: compound 4; then compounds 1 and 3 (each within the scatter of the next). At a limit, above all of these: compound 2.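

Up to this point, no change in the group on the carbon with a double bond to nitrogen had gone beyond the scatter in this assay, but nitro in place of methyl, on an aromatic carbon meta to a large group, gives an at least 6.5-fold lower number from compound 2 to compound 4 (0.81 log units; beyond the scatter). Going by these compounds, compound 2 sits at a limit of the assay and not at a number, so the size of that step stays open and only its floor can be read: the limit of > 100000 nM in this assay, at which 1 of the 4 values shown sits. The 3-nitrophenyl also stands apart from the other two groups, with a 5.7-fold lower number from compound 3 to compound 4 (0.76 log units; beyond the scatter) and a 4.8-fold lower number from compound 1 to compound 4 (0.68 log units; beyond the scatter), so among the four compounds the groups at this position do not all give the same result, and compound 4 is the strongest of them in this assay.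

The compounds shown do not tell whether this step belongs to nitro itself or to nitro at this place on the ring, and they offer no measured property that would account for it. On these data alone, what an amine, a nitrile or a carboxylic acid would give on the same aromatic carbon remains open.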